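The compounds below may be only part of what the source reports. "The series", "measured", "known", "first", "only" and "open" are said of these compounds alone.

Compound 1 `CC(C)[C@H](NC(=O)c1cc(Cl)ccc1OCCN)C(=O)Nc1ccc([N+](=O)[O-])cc1Cl` — > 10000 nM
Compound 2 `CC(C)[C@H](NC(=O)c1cc(Cl)ccc1OCCCNC(=O)OC(C)(C)C)C(=O)Nc1ccc([N+](=O)[O-])cc1Cl` — > 10000 nM
Compound 3 `CC(C)[C@H](NC(=O)c1cc(Cl)ccc1OCCCN)C(=O)Nc1ccc([N+](=O)[O-])cc1Cl` — 6770 nM

Three compounds built on one shared core were tested in a functional assay on MDA-MB-231 cells (Homo sapiens) for inhibition, read by MTT assay, with a stated time of 72 h; a lower number here means a stronger inhibitor, a higher number a weaker inhibitor. Compound 1 reaches only a limit of the assay, > 10000 nM. Compound 2 likewise sits at a limit, > 10000 nM. Among the compounds with values here, compound 3 is the only one to give a number in this assay, 6770 nM. The core of compound 3 differs from that of compound 1 by aminomethyl in place of amino on a saturated chain carbon, two bonds along the chain from an oxygen on an aromatic ring, which gives an at least 1.4-fold lower number from compound 1 to compound 3 (0.16 log units; that floor lies within the scatter). Compound 2 differs from compound 1 by ((tert-butoxycarbonyl)amino)methyl in place of amino on a saturated chain carbon, two bonds along the chain from an oxygen on an aromatic ring; the step is a step that the two limits leave unreadable from compound 1 to compound 2, since both values sit at the limit of > 10000 nM in this assay, at which 2 of the 3 values shown sit. From compound 2 to compound 3 the step is an at least 1.4-fold lower number from compound 2 to compound 3 (0.16 log units; that floor lies within the scatter).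

Compound 4 `CC(C)[C@H](NC(=O)c1cc(Cl)ccc1OCCCCNC(=O)OC(C)(C)C)C(=O)Nc1ccc([N+](=O)[O-])cc1Cl` has not yet been measured. It differs from compound 3 by ((tert-butoxycarbonyl)amino)methyl in place of amino on a saturated chain carbon, three bonds along the chain from an oxygen on an aromatic ring. This is the same kind of change as that from compound 1 to compound 2, but here it sits three bonds along the chain from an oxygen on an aromatic ring rather than two. The earlier step, a step that the two limits leave unreadable from compound 1 to compound 2, gives no readable size. The step from compound 3 to compound 4 is expected to be a 2.2-fold higher number from compound 3 to compound 4 (0.35 log units; beyond the scatter), because the reverse change gave an at least 1.4-fold lower number from compound 2 to compound 3 (0.16 log units; that floor lies within the scatter) in this assay. Compound 4 is therefore estimated at 15000 nM, with a range from 6000 nM to 40000 nM, and a limit rather than a number is thought likely.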

Compound 4, half-maximal inhibitory concentration: > 10000 nM
Compound 4: a limit, no number; the forecaster's own chance of this, stated with the estimate: 65%; the middle value does not contradict the limit.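

Set on the 3-aminopropyl chain of compound 3, the change to 4-((tert-butoxycarbonyl)amino)butyl in this assay gives an at least 1.4-fold higher number from compound 3 to compound 4 (0.16 log units; that floor lies within the scatter), and this is a floor and not a measured size. Within the data shown here, it shows only that on this core the change gives no lower number, and it does not show that the change acts alike on the core of compound 1, since the same kind of change from compound 1 to compound 2 has no readable size. That step and the new steps to compound 4 from compound 1 and from compound 2 cannot be read, and no size can be carried from one core to another, because both ends of each step sit at the same limit: the limit of > 10000 nM in this assay, at which 3 of the 4 values shown sit.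

Among these compounds, compound 3 remains the only compound with a number, 6770 nM, so it is open whether that number depends on the 3-aminopropyl chain in particular. As far as these compounds go, what a 4-aminobutyl chain would give in this assay, with its free amine at the end of the longer chain, stays open, as does a carboxylic acid at the end of the chain.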